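Working notes on the step from compound 2 to compound 3

This account rests on a few compounds, and the source may have more. Where it says the series, first, only, none or still open, it means among the compounds named here.

compound 1 `CC(C)N(Cc1cccc(OCCCCCC(=O)O)c1)C(=O)c1ccccc1`: > 26000 nM
compound 2 `CC(=O)c1cccc(-c2ccc(C(=O)N(Cc3cccc(OCCCCCC(=O)O)c3)C(C)C)cc2)c1`: > 26000 nM

In an ADME assay on Raji cells (Homo sapiens) for cytotoxicity, read by CellTiter-Glo and resazurin assay, with a stated time of 72 h (a lower number here means that less compound is needed, a higher number that more compound is needed for the effect), compound 1 gives > 26000 nM, which is a limit of the assay. Compound 2 in this assay gives > 26000 nM, also a limit. Compound 2 thus stands only at a limit, and the step that the two limits leave unreadable from compound 1 to compound 2 cannot be read; the limit of > 26000 nM in this assay, at which 2 of the 2 values shown sit, holds both measured values. Compound 3 `CC(C)COc1cccc(-c2ccc(C(=O)N(Cc3cccc(OCCCCCC(=O)O)c3)C(C)C)cc2)c1` carries isobutoxy in place of acetyl on an aromatic carbon. No readable measured step bears on this change. Compound 3 is expected to stay at the limit, with an estimate of 30000 nM and a range from 10000 nM to 100000 nM. The expected step is a step that the limit leaves unreadable from compound 2 to compound 3, no change beyond the scatter.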

Compound 3, half-maximal effective concentration: > 26000 nM
Compound 3 was reported as a limit; the forecaster's own chance of this, stated with the estimate: 85%; the middle value does not contradict the limit.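

No new step can be read from compound 2 or compound 3, as each is reported only as a limit: the limit of > 26000 nM in this assay, at which 3 of the 3 values shown sit.
Still open is how 3-acetylphenyl and 3-(isobutoxy)phenyl compare in this assay, since no compound shown gives a value that is more than a limit.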